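From compound 3 to compound 4: a chlorine moves

A few compounds are considered here, and "the series" means these few. Any claim that something is new, unique, unknown or untested is made for them only; others in the source may bear on it.

Values in a functional assay on DU-145 cells (Homo sapiens) for cytotoxicity, read by CCK-8 assay and cell counting, with a stated time of 2 days (on this read-out higher numbers stand for weaker inhibition and lower numbers for stronger inhibition), are as follows:
compound 1 `Oc1ccc(-c2cc(-c3cccc(Cl)c3)nc(-c3ccccn3)c2)cc1` gives 35200 nM
compound 2 `Oc1ccc(-c2cc(-c3cccc(Cl)c3)nc(-c3cccs3)c2)cc1` gives 5740 nM
compound 3 `Oc1ccc(-c2cc(-c3ccsc3)nc(-c3ccccc3Cl)c2)cc1` gives 3890 nM

Compound 3 lies within the scatter of compound 2 and well below compound 1. Compound 4 `Oc1ccc(-c2cc(-c3ccsc3)nc(-c3cccc(Cl)c3)c2)cc1` takes 3-chlorophenyl in place of the 2-chlorophenyl of compound 3 on an aromatic carbon, and 3-chlorophenyl in place of 2-chlorophenyl on an aromatic carbon is all that separates them. Within the data shown here, no measured step makes this swap. Among the measured compounds shown here, the single step available, a 6.1-fold lower number from compound 1 to compound 2 (0.79 log units; beyond the scatter), is modest and exchanges pyridin-2-yl for thiophen-2-yl, so it bears only indirectly. Compound 4 shares its 3-chlorophenyl group with compound 2 at 5740 nM in this assay, so no change beyond the scatter is expected. The expected step is a 1.2-fold higher number from compound 3 to compound 4 (0.06 log units; within the scatter) on this reasoning. Compound 4 is estimated at 4500 nM within a range of 1500 nM to 13000 nM in this read-out.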

Compound 4, half-maximal inhibitory concentration: 6220 nM
Compound 4: middle estimate off by 1.4-fold (0.14 log units), on the low side; the measured number falls inside the stated range.
By their numbers in this assay, from the lowest: compounds 3, 2 and 4 (each within the scatter of the next); then compound 1.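

In this assay, moving the chlorine from 2-chlorophenyl to 3-chlorophenyl, at the position next to the ring nitrogen, stays within the scatter (a 1.6-fold higher number from compound 3 to compound 4 (0.20 log units; within the scatter)). Thiophen-3-yl in place of thiophen-2-yl also stays within the scatter (a 1.1-fold higher number from compound 2 to compound 4 (0.03 log units; within the scatter)), while thiophen-3-yl in place of pyridin-2-yl goes beyond it (a 5.7-fold lower number from compound 1 to compound 4 (0.75 log units; beyond the scatter)), so thiophen-2-yl and thiophen-3-yl both stand apart from pyridin-2-yl. Nothing available explains these steps. Going by these compounds, it remains open whether 4-chlorophenyl or an aminophenyl group at this position would move the number beyond the scatter.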